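Cytotoxicity of a Methoxy-Methyl Aryl Amide Variant

This account rests on a few compounds, and the source may have more. Where it says the series, first, only, none or still open, it means among the compounds named here.

Three measured compounds share one core and differ in the ring on the amide nitrogen and in the group on the imide nitrogen. Compound 1 `CCCCCN1C(=O)C/C(=C\c2cccc(C(=O)Nc3ccc(C)cc3)c2)C1=O` carries a pentyl chain on the imide nitrogen, while compound 2 `Cc1ccc(NC(=O)c2cccc(/C=C3\CC(=O)N(c4ccccc4)C3=O)c2)cc1C` and compound 3 `Cc1cccc(NC(=O)c2cccc(/C=C3\CC(=O)N(c4ccccc4)C3=O)c2)c1` carry a phenyl there. In an ADME assay on NCM460 cells (Homo sapiens) for cytotoxicity, read by MTT assay, with a stated time of 72 h (on this read-out lower numbers stand for stronger inhibition and higher numbers for weaker inhibition), compound 1 gives > 100000 nM, which is a limit of the assay rather than a number. In this assay compound 2 gives > 100000 nM, also a limit. Compound 3 gives > 100000 nM in this assay, again a limit. Compound 3 thus stands where every measured compound stands, at the limit with no number read (the limit of > 100000 nM in this assay, at which 3 of the 3 values shown sit).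

The step from compound 2 to compound 3, hydrogen in place of methyl on an aromatic carbon, reads a step that the two limits leave unreadable from compound 2 to compound 3, so no size can be drawn from it.

Compound 4 `COc1ccc(NC(=O)c2cccc(/C=C3\CC(=O)N(c4ccccc4)C3=O)c2)c(C)c1` differs from compound 3 by 4-methoxy-2-methylphenyl in place of 3-methylphenyl on an amide-type nitrogen. Going by the values given here, no measured step bears on a methoxy group on this ring, and the one step that touches the ring is unreadable. With all measured values sitting at the limit, the expected step is a step that the limit leaves unreadable from compound 3 to compound 4, meaning no change beyond the scatter. Compound 4 is therefore estimated to give about 150000 nM in this assay, within 60000 nM to 400000 nM, most likely reported again only as a limit.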

Compound 4, half-maximal inhibitory concentration: > 100000 nM
Compound 4 ended at the assay's limit; the forecaster's own chance of this, stated with the estimate: 85%; the middle value is on the limit's open side.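

In this assay compound 4 gives > 100000 nM, again a limit and not a number. The steps joining compound 4 to compound 2 and to compound 3 therefore cannot be read: the limit of > 100000 nM in this assay, at which 4 of the 4 values shown sit.

Left open is whether the ring on the amide nitrogen or the group on the imide nitrogen changes cytotoxicity at all.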